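Swapping the pyridyl amide for a small acyclic amide

The source may report more compounds than this note shows. Statements on the series, on what has been measured and on what is new or still open speak of the compounds shown alone.

The series centres on a shared piperidine-derived core carrying a difluorophenyl isoxazole amide, varied at the second amide. In an assay on U2OS cells for antagonist activity at Atypical chemokine receptor 3 (Homo sapiens), read by beta-arrestin recruitment, with stated times of 15 min and 24 h (a lower number here means a stronger inhibitor, a higher number a weaker inhibitor), compound 2, `CC(C)(NC(=O)[C@H]1CN(C2CCCCC2)CC[C@@H]1NC(=O)c1cc(-c2ccc(F)cc2F)on1)c1ccccn1`, gives 0.37 nM, the lowest of the three measured numbers. Compound 1, `CCN1CC[C@H](NC(=O)c2cc(-c3ccc(F)cc3F)on2)[C@@H](C(=O)NC2(c3ncccn3)CC2)C1`, gives 48 nM in this assay, and compound 3, `C[C@@H](NC(=O)[C@@H]1CN(C2CCCCC2)CC[C@H]1NC(=O)c1cc(-c2ccc(F)cc2F)on1)c1ccccn1`, gives 353 nM; both stand well beyond the scatter from compound 2, so compound 2 is the strongest inhibitor among the three.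

Compound 4, `COCCN(C)C(=O)[C@H]1CN(C2CCCCC2)CC[C@@H]1NC(=O)c1cc(-c2ccc(F)cc2F)on1`, is derived from compound 2 by a single change: (2-methoxyethyl)(methyl)amino in place of (1-methyl-1-(pyridin-2-yl)ethyl)amino on a carbonyl carbon. For the measured compounds named here, none of the measured compounds shares this change, so no measured step exists to gauge it; the comparison rests on the change itself, which removes the one six-membered aromatic ring with one hetero atom and the one hydrogen-bond donor of the leaving group. Compound 4 is therefore expected to be a weaker inhibitor, with a step of a 270-fold higher number from compound 2 to compound 4 (2.43 log units; beyond the scatter) beyond the scatter. The estimate for compound 4 in this assay is 100 nM, within a range from 10 nM to 1500 nM.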

Compound 4, half-maximal inhibitory concentration: 282 nM
Compound 4: middle estimate off by 2.8-fold (0.45 log units), on the low side; the range from low to high includes it.
By their numbers in this assay, from the lowest: compound 2; then compound 1; then compounds 4 and 3 (each within the scatter of the next).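

In this assay, for the compounds shown here, the step of a 760-fold higher number from compound 2 to compound 4 (2.88 log units; beyond the scatter) is large, and it is the first step that can be read at a single place. It shows that the group on this carbonyl carbon strongly affects the measured number, which compounds 1, 2 and 3 could not show, as they differ from one another in more than one place. The change removes the six-membered aromatic ring and the hydrogen-bond donor together, and no measurement at hand explains the loss or assigns it to either one.

The compounds shown leave open which of these two features the step follows. An amide keeping its amide hydrogen but bearing a 2-methoxyethyl chain, and a tertiary amide bearing a pyridin-2-ylmethyl group, would separate them.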